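A few compounds are considered here, and "the series" means these few. Any claim that something is new, unique, unknown or untested is made for them only; others in the source may bear on it.

Working notes on the series. Among the measured compounds shown here, the shared core is carried by compound 1 `OCC1CCN(c2nccnc2OC2CN(c3cnc4ccccc4n3)C2)CC1` and compound 2 `c1ccc(-c2nccnc2OC2CN(c3ccc4ccccc4n3)C2)cc1`; the two differ in more than one place, so no single step joins them. In a physicochemical assay for solubility, in phosphate buffer, at pH 7.4 (on this read-out lower numbers stand for lower solubility and higher numbers for higher solubility), compound 1 gives 500000 nM. Compound 2 reaches only a limit of this assay, < 1000 nM, and no number; it therefore sits at the limit of < 1000 nM in this assay, at which 1 of the 2 values shown sits, the lower edge of what the series shows. The untested member is compound 3 `CS(=O)(=O)N1CCC(c2nccnc2OC2CN(c3ccc4ccccc4n3)C2)CC1`. Relative to compound 2 the change is 1-(methylsulfonyl)piperidin-4-yl in place of phenyl on an aromatic carbon. For the measured compounds named here, with no measured step available, the direction is taken from compound 2 alone: its value is a limit, so any numerical reading for compound 3 would place the move upward, and a step of moderate to large size toward higher solubility is expected, written as an at least 20-fold higher number from compound 2 to compound 3 (1.30 log units; beyond the scatter). Compound 3 is estimated at 20000 nM, within the range 2000 nM to 200000 nM.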

Compound 3, solubility: 181000 nM
Compound 3: middle estimate off by 9.1-fold (0.96 log units), on the low side; measured number inside the range.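

In this assay, among the compounds shown here, the change of phenyl to 1-(methylsulfonyl)piperidin-4-yl on an aromatic carbon of a six-membered aromatic ring with 2 nitrogen gives the first single-place step: an at least 180-fold higher number from compound 2 to compound 3 (2.25 log units; beyond the scatter). Compound 2 has only a limit in this read-out, < 1000 nM, and no number. The step therefore gives a minimum for this change, and its true size cannot be read: the limit of < 1000 nM in this assay, at which 1 of the 3 values shown sits.

The change replaces the aromatic ring of carbon only with a non-aromatic ring and also brings in the methylsulfonyl group, so the compounds shown leave open which of these parts accounts for the step. Also open, from the compounds shown here alone, is how a free amine on the piperidine nitrogen, or a carboxylic acid on the same aromatic carbon, would read in this assay.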